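Restoring a pyridinylmethyl group on the ring nitrogen

A few compounds are considered here, and "the series" means these few. Any claim that something is new, unique, unknown or untested is made for them only; others in the source may bear on it.

Measured so far in a functional assay on A-375 cells (Homo sapiens) for antiproliferative activity, read by CCK-8 assay, with a stated time of 72 h, tested at 8 uM; a higher number here means a stronger effect of the compound at the concentration tested, a lower number a weaker effect:
Compound 1, `Nc1ccccc1NC(=O)c1ccc(CSC(=S)N2CCN(Cc3ccccn3)CC2)cc1`, gives 82.4%.
Compound 2, `Nc1ccccc1NC(=O)c1ccc(CSC(=S)N2CCN(c3cccnc3)CC2)cc1`, gives 88.8%.
Compound 3, `N#Cc1ccc(N2CCN(C(=S)SCc3ccc(C(=O)Nc4ccccc4N)cc3)CC2)cc1`, gives 62.9%.

Compound 3 stands lowest of the three numbers. Both steps that lead to it lie beyond the scatter: a number 19.5 percentage points lower from compound 1 to compound 3 (beyond the scatter) and a number 25.9 percentage points lower from compound 2 to compound 3 (beyond the scatter). Compound 3 is therefore the weakest of the measured set in this assay. Between compound 1 and compound 2 the step is a number 6.4 percentage points higher from compound 1 to compound 2 (within the scatter), so the two pyridine-bearing groups on that ring nitrogen read alike.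

Compound 4, `Nc1ccccc1NC(=O)c1ccc(CSC(=S)N2CCN(Cc3ccncc3)CC2)cc1`, differs from compound 3 in one place: (pyridin-4-yl)methyl in place of 4-cyanophenyl on an amine nitrogen in a ring. Among the compounds with values here, the steps that bear on this change are the two that brought the 4-cyanophenyl group in, a number 19.5 percentage points lower from compound 1 to compound 3 (beyond the scatter) and a number 25.9 percentage points lower from compound 2 to compound 3 (beyond the scatter), both of modest size and both downward. The move to compound 4 reverses that swap, so a modest rise in this assay is expected rather than a fall or no change. For compound 4 the expected step is a number 17.1 percentage points higher from compound 3 to compound 4 (beyond the scatter). Compound 4 is estimated at 80%, with a range from 66% to 92%.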

Compound 4, a percentage reported as inhibition, at one concentration (the size of the read-out at that concentration, not a potency): 89.5%
For compound 4 the middle estimate is 9.5 percentage points below the measured one; measured number inside the range.
By their numbers in this assay, from the lowest: compound 3; then compounds 1, 2 and 4 (each within the scatter of the next).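

In this assay, the swap away from 4-cyanophenyl gives a number 26.6 percentage points higher from compound 3 to compound 4 (beyond the scatter), so a third pyridine-bearing group on this ring nitrogen stands clear of compound 3. The pyridine variations themselves make little visible difference: moving the attachment from pyridin-2-yl to pyridin-4-yl on the methyl link gives a number 7.1 percentage points higher from compound 1 to compound 4 (within the scatter), and exchanging pyridin-3-yl for (pyridin-4-yl)methyl gives a number 0.7 percentage points higher from compound 2 to compound 4 (within the scatter). Compounds 1, 2 and 4 therefore read alike at this single concentration, whether or not a methyl link is present.

No measurement offered here explains the gap between these groups and 4-cyanophenyl. Still open, as far as these compounds go, is whether that gap follows the nitrile or the carbon-only aromatic ring, a question that a plain benzyl or phenyl group on this ring nitrogen would address.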